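Notes on the aryl acid change in this series

This account rests on a few compounds, and the source may have more. Where it says the series, first, only, none or still open, it means among the compounds named here.

Measured so far:
`O=C(O)c1cc(-c2cccc(COc3ccc4c(=O)n(C5CCC5)sc4c3)c2)ccc1Cl` — compound 1, 580 nM
`O=C(O)c1ccc(-c2cccc(COc3ccc4c(c3)CN(C3CCCC3)C4=O)c2)c(Cl)c1` — compound 2, 110 nM
`O=C(O)c1cc(-c2cccc(COc3ccc4c(=O)n(C5CC5)sc4c3)c2)ccc1Cl` — compound 3, 130 nM

In an assay on HEK293 cells for positive allosteric modulation of metabotropic glutamate receptor 2 (Rattus norvegicus), read by thallium flux (on this read-out lower numbers stand for an effect already at smaller amounts and higher numbers for an effect only at larger amounts of compound), compound 2 stands at the lowest of the three numbers, with compound 3 within the scatter of it and compound 1 clearly higher. Among the compounds with values here, the only step between measured compounds that differ in one place is a 4.5-fold lower number from compound 1 to compound 3 (0.65 log units; beyond the scatter), a cyclopropyl for cyclobutyl swap on an aromatic nitrogen of the shared core; it does not bear on the aryl acid change. Compound 4, `COc1ccc(-c2cccc(COc3ccc4c(c3)CN(C3CCCC3)C4=O)c2)cc1C(=O)O`, differs from compound 2 by 3-carboxy-4-methoxyphenyl in place of 4-carboxy-2-chlorophenyl on an aromatic carbon. Within the data shown here, no measured pair shows this change, so the direction is open; a modest drift to higher numbers is assumed with wide bounds. Compound 4 is expected near 250 nM (range 60 nM to 1000 nM); that is, a 2.3-fold higher number from compound 2 to compound 4 (0.36 log units; beyond the scatter) is expected.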

Compound 4, half-maximal effective concentration: 170 nM
Compound 4: the middle estimate sits 1.5-fold (0.17 log units) above what was measured, and the stated range covers the measured number.
By their numbers in this assay, from the lowest: compounds 2, 3 and 4 (each within the scatter of the next); then compound 1.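

In this assay the swap of 4-carboxy-2-chlorophenyl for 3-carboxy-4-methoxyphenyl gives a 1.5-fold higher number from compound 2 to compound 4 (0.19 log units; within the scatter) and leaves both compounds within the scatter of each other, so this position tolerates this change on the shared core. The swap alters the carboxy placement and the second group together, and the two contributions cannot be separated here. Nothing on hand explains the result.

Open, on these data alone, is whether 3-carboxy-4-chlorophenyl would separate those two contributions. Also open, as far as these compounds go, is whether a tetrazole or a primary amide could stand in place of the carboxylic acid at this position.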